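Replacing the Phenyl Group with a Hydroxybutynyl Chain

This account rests on a few compounds, and the source may have more. Where it says the series, first, only, none or still open, it means among the compounds named here.

Compound 1, `C/C=C1\C=C(C)C2(CC2)C(C)(O)C1=O`, in a functional assay on A-375 cells (Homo sapiens) for antiproliferative activity (on this read-out lower numbers stand for stronger inhibition and higher numbers for weaker inhibition), gives 4 nM.
Compound 2, `CC1=C/C(=C\c2ccccc2)C(=O)C(C)(O)C12CC2`, in this assay gives > 10000 nM.

The value shown for compound 2 is a limit of this assay and not a number, so compound 2 stands at the weak end of the two results, at the limit of > 10000 nM in this assay, at which 1 of the 2 values shown sits. Compound 3, `CC1=C/C(=C\C#CCCO)C(=O)C(C)(O)C12CC2`, differs from compound 2 in one place: 4-hydroxybut-1-yn-1-yl in place of phenyl on a double-bonded chain carbon bound to a double-bonded ring carbon. Going by the values given here, the only measured step, an at least 2500-fold higher number from compound 1 to compound 2 (3.39 log units; beyond the scatter), concerns the same carbon and shows that putting phenyl there in place of methyl cost a great deal of inhibition. Among the compounds with values here, no measured step covers a chain bearing a triple bond and a hydroxyl at that carbon, so the step from compound 2 to compound 3 is uncertain in size. Because the loss in an at least 2500-fold higher number from compound 1 to compound 2 (3.39 log units; beyond the scatter) came with the phenyl group, removing it is expected to regain some inhibition without reaching compound 1. Compound 3 is therefore estimated at 2000 nM in this assay, between 150 nM and 15000 nM, an expected step of an at least 5.0-fold lower number from compound 2 to compound 3 (0.69 log units; beyond the scatter).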

Compound 3, half-maximal inhibitory concentration: 2000 nM
Beside the measured number, compound 3's estimate shows no gap at the digits printed; the range from low to high includes it.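

Compound 2's > 10000 nM is a limit of this assay and not a number. Putting 4-hydroxybut-1-yn-1-yl in place of phenyl brings back a measurable level of inhibition, with an at least 5.0-fold lower number from compound 2 to compound 3 (0.69 log units; beyond the scatter). Even so, the chain falls far short of the methyl group, with a 500-fold higher number from compound 1 to compound 3 (2.70 log units; beyond the scatter), so the large loss at this carbon does not depend on an aromatic ring, since compound 3 has no ring and still loses most of the inhibition of compound 1.

The compounds shown do not separate the contribution of the triple bond from that of the hydroxyl group. Also open, as far as these compounds go, is how an ethyl group, a longer chain, or a chain ending in an amine or a carboxylic acid would behave on this carbon.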